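Solubility After Swapping Isobutyl for 2-Methoxyphenoxy

The compounds below may be only part of what the source reports. "The series", "measured", "known", "first", "only" and "open" are said of these compounds alone.

Of the compounds shown here, three sharing one core have been measured in a physicochemical assay for solubility, with a stated time of 18 h, at pH 7.4; on this read-out higher numbers stand for higher solubility and lower numbers for lower solubility. Compound 1 `COc1cccc(CNCCCNc2ccnc3cc(Oc4ccccc4)ccc23)c1O` gives 14500 nM. Compound 2 `COc1cccc(CNCCCNc2ccnc3cc(Cc4ccc(F)cc4)ccc23)c1O` gives 4200 nM, and compound 3 `COc1cccc(CNCCCNc2ccnc3cc(CC(C)C)ccc23)c1O` gives 4200 nM. Compound 3 is level with compound 2 at the digits reported, the two standing together at the lowest number of the three, while the step of a 3.5-fold lower number from compound 1 to compound 3 (0.54 log units; beyond the scatter) sets compound 1 apart as the higher value.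

Compound 4 `COc1ccccc1Oc1ccc2c(NCCCNCc3cccc(OC)c3O)ccnc2c1` is unmeasured. The change from compound 3 is 2-methoxyphenoxy in place of isobutyl on an aromatic carbon. The step that bears on it most is a 3.5-fold lower number from compound 1 to compound 3 (0.54 log units; beyond the scatter), since compound 4 returns a phenoxy-type group to the position where compound 3 carries isobutyl; the step of a 3.5-fold lower number from compound 1 to compound 2 (0.54 log units; beyond the scatter) points the same way. Among the compounds with values here, no measured pair tests the added methoxy on the entering group. Compound 4 is therefore expected to show a modest rise, a 2.9-fold higher number from compound 3 to compound 4 (0.46 log units; beyond the scatter), in this assay. The estimate for compound 4 is 12000 nM, with a range from 5000 nM to 30000 nM.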

Compound 4, solubility: 14500 nM
Compound 4: middle estimate off by 1.2-fold (0.08 log units), on the low side; the range from low to high includes it.
By their numbers in this assay, from the lowest: compounds 2 and 3 (each within the scatter of the next); then compounds 1 and 4 (each within the scatter of the next).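

In this assay, a second group bound through oxygen at this aromatic carbon stands clear of the carbon-bound groups, with a 3.5-fold higher number from compound 3 to compound 4 (0.54 log units; beyond the scatter) and a 3.5-fold higher number from compound 2 to compound 4 (0.54 log units; beyond the scatter); among these four compounds, none goes against that split. Within the data shown here, the added methoxy, which no earlier pair tested, gives no change at the digits printed from compound 1 to compound 4 (within the scatter), so on this read-out the phenoxy and 2-methoxyphenoxy groups cannot be told apart. Nothing available explains why these groups separate as they do.

As far as these compounds go, whether the level shared by compound 1 and compound 4 extends to other oxygen-bound groups, such as ethoxy, or to an amine or a carboxylic acid on this carbon, remains open. From the compounds shown here alone, it is also open whether a methoxy on another carbon of the entering ring would behave as this one does.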